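The source may hold more compounds than are shown below. What is called first, only, known or untested is meant among the compounds shown, and "the series" means these compounds.

Measured in a functional assay on A549 cells (Homo sapiens) for cytotoxicity, read by MTT assay, with a stated time of 72 h; on this read-out higher numbers stand for weaker inhibition and lower numbers for stronger inhibition:
Compound 1 `O=C(N/N=C/c1ccc(O)cc1O)Nc1cc2c(Nc3ccc(F)c(Cl)c3)ncnc2cc1O[C@H]1CCOC1`: 9360 nM
Compound 2 `COc1ccc(/C=N/NC(=O)Nc2cc3c(Nc4ccc(F)c(Cl)c4)ncnc3cc2OC)cc1`: 28100 nM

Going by the values given here, of these two numbers, the one for compound 2, 28100 nM, is the higher, and compound 1 lies below it by more than the scatter. Compound 3 `COc1cc2ncnc(Nc3ccc(F)c(Cl)c3)c2cc1NC(=O)N/N=C/c1ccc(O)cc1O` has not yet been measured. It differs from compound 2 in one place: 2,4-dihydroxyphenyl in place of 4-methoxyphenyl on a carbon with a double bond to nitrogen. In words, 2,4-dihydroxyphenyl stands in place of 4-methoxyphenyl on a carbon with a double bond to nitrogen. The same 2,4-dihydroxyphenyl group is present in compound 1, which gives 9360 nM, although that compound also differs elsewhere on the core. A moderate fall in the number, meaning stronger inhibition, is therefore expected in this assay, probably only a little beyond the scatter. The estimated change is a 2.2-fold lower number from compound 2 to compound 3 (0.33 log units; beyond the scatter). For compound 3 the expected value is 13000 nM, with an estimated range of 5000 nM to 30000 nM.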

Compound 3, half-maximal inhibitory concentration: 31400 nM
Compound 3: the middle estimate sits 2.4-fold (0.38 log units) below what was measured; measured number outside the range, above it.
By their numbers in this assay, from the lowest: compound 1; then compounds 2 and 3 (each within the scatter of the next).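

In this assay, 2,4-dihydroxyphenyl in place of 4-methoxyphenyl on a carbon with a double bond to nitrogen gives a 1.1-fold higher number from compound 2 to compound 3 (0.05 log units; within the scatter), so on this core the exchange cannot be told apart from the scatter. With 2,4-dihydroxyphenyl held constant, methyl in place of oxolan-3-yl on an oxygen on an aromatic ring gives a 3.4-fold higher number from compound 1 to compound 3 (0.53 log units; beyond the scatter), which places the lower number of compound 1 with that oxygen substituent and not with 2,4-dihydroxyphenyl alone. Nothing available explains why one exchange registers in this read-out and the other does not.

From the compounds shown here alone, it remains open whether 4-methoxyphenyl would give a similar number alongside oxolan-3-yl on that oxygen. Also open, going by these compounds, is how a longer chain or an amine in place of methyl on that oxygen would compare.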